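The source may hold more compounds than are shown below. What is called first, only, known or untested is meant among the compounds shown, and "the series" means these compounds.

Compound 2, `N#CC1=C(N)N(c2ccc(S(N)(=O)=O)cc2)C2=C(CCCC2)C1c1c(O)ccc2ccccc12`, gives 20% in a functional assay on Ehrlich cells (Mus musculus) for cytotoxicity, read by trypan blue exclusion, with a stated time of 2 h, tested at 50 ug/mL; on this read-out higher numbers stand for a stronger effect at the one concentration tested and lower numbers for a weaker effect; this is the lower of the two numbers measured. Compound 1, `COc1ccccc1C1C(C#N)=C(N)N(c2ccc(S(N)(=O)=O)cc2)C2=C1CCCC2`, gives 50% in this assay, and the step of a number 30 percentage points lower from compound 1 to compound 2 (beyond the scatter) goes with the exchange of 2-methoxyphenyl for 2-hydroxynaphthalen-1-yl on a saturated ring carbon. Compound 3, `COc1ccc2ccccc2c1C1C(C#N)=C(N)N(c2ccc(S(N)(=O)=O)cc2)C2=C1CCCC2`, is not yet measured; it differs from compound 2 by methyl in place of hydrogen on an oxygen on an aromatic ring. For the measured compounds named here, the one measured step bears on this change only indirectly, since it swapped the whole aryl group at once and so does not separate the methyl on the oxygen from the larger ring. Still, compound 3 carries the methoxy group that compound 1 also carries, and compound 1 stands higher. Compound 3 is therefore expected to come out somewhat higher, by an estimated a number 12 percentage points higher from compound 2 to compound 3 (beyond the scatter), though a change within the scatter remains possible. The estimate for compound 3 is 32%, with a range from 12% to 55%.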

Compound 3, a percentage reported as activity, at one concentration (the size of the read-out at that concentration, not a potency): 10%
Compound 3: middle estimate off by 22 percentage points, on the high side; measured number below the stated range.
By their numbers in this assay, from the lowest: compounds 3 and 2 (each within the scatter of the next); then compound 1.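

The new step, a number 10 percentage points lower from compound 2 to compound 3 (within the scatter), shows that in this assay hydroxy to methoxy on this oxygen on an aromatic ring leaves no difference beyond the scatter when the larger aryl group is kept. For the compounds shown here, the step of a number 30 percentage points lower from compound 1 to compound 2 (beyond the scatter) had changed the whole aryl group at once, so it could not show this; the methoxy group of compound 1 does not by itself give compound 3 a number near the one printed for compound 1, as compound 1 gives 50% and compound 3 gives 10% in this read-out. Nothing at hand gives a reason for either step.

From the compounds shown here alone, what an ethyl group or a longer chain on this oxygen would give remains open, as does an amine in place of the hydroxy group. Also open, going by these compounds, is how a 2-hydroxyphenyl group would compare with the 2-methoxyphenyl group of compound 1.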